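The source may report more compounds than this note shows. Statements on the series, on what has been measured and on what is new or still open speak of the compounds shown alone.

Measured so far in an assay on cells for inhibition of Palmitoleoyl-protein carboxylesterase NOTUM variant C330S (Homo sapiens), read by fluorescence, with a stated time of 40 min; on this read-out higher numbers stand for weaker inhibition and lower numbers for stronger inhibition:

Compound 1 `Cc1cccc(-n2c(C)cc(C(=O)O)c2C)c1` gives 1500 nM.
Compound 2 `Cc1ccc(-n2c(C)cc(C(=O)O)c2C)cc1` gives 2000 nM.
Compound 3 `Cc1cc(C(=O)O)c(C)n1-c1cccc(Cl)c1` gives 430 nM.

Compound 1 and compound 2 carry the same atoms joined differently; the difference between these two cores is not broken down here, and their two values lie within the scatter of each other. Compound 3 arises from compound 1 by one change, (chloro in place of methyl on an aromatic carbon), and this change made the step of a 3.5-fold lower number from compound 1 to compound 3 (0.54 log units; beyond the scatter).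

Compound 4 `Cc1cc(C(=O)O)c(C)n1-c1ccc(Cl)cc1` has not yet been measured. It arises from compound 2 by chloro in place of methyl on an aromatic carbon. The change is the same kind of change as that from compound 1 to compound 3, but not the same: in compound 3 the chloro sits meta to a large group, whereas in compound 4 it sits para to a large group. Resting on the step from compound 1 to compound 3, the step from compound 2 to compound 4 in this assay is expected to be a 3.1-fold lower number from compound 2 to compound 4 (0.49 log units; beyond the scatter). Compound 4 is therefore estimated at 650 nM, most likely between 300 nM and 1500 nM.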

Compound 4, half-maximal inhibitory concentration: 860 nM
Compound 4: middle estimate off by 1.3-fold (0.12 log units), on the low side, within the range that was stated.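

In this assay, chloro in place of methyl on an aromatic carbon lowered the number on a second core, with a 2.3-fold lower number from compound 2 to compound 4 (0.37 log units; beyond the scatter). Set beside the earlier step, the change carried over in direction, and the two steps cannot be told apart in size: the same change on two cores in this assay, a 3.5-fold lower number (0.54 log units; beyond the scatter) from compound 1 to compound 3 and a 2.3-fold lower number (0.37 log units; beyond the scatter) from compound 2 to compound 4, 1.5-fold (0.18 log units) apart, within the scatter of two such steps This rests on two cores only, so it does not show that the change would hold on any other core in the series, and it gives no reason why the number falls.

The compounds shown leave open whether another group on the aromatic ring, such as fluoro, trifluoromethyl or methoxy, would follow the same course as chloro. They also leave open what happens on the shared core when an amide or a nitrile stands in place of the carboxylic acid, or when a longer chain such as ethyl stands in place of its methyl groups.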